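Chain amine variation on a bis(trifluoromethyl)benzenesulfonamide series

The compounds below may be only part of what the source reports. "The series", "measured", "known", "first", "only" and "open" are said of these compounds alone.

Measured so far:
compound 1 `O=S(=O)(NCCCNCc1ccccc1Cl)c1cc(C(F)(F)F)cc(C(F)(F)F)c1`: 9300 nM in a functional assay on A2780 cells (Homo sapiens) for inhibition, read by MTT assay, with a stated time of 72 h; a lower number here means a stronger inhibitor of growth, a higher number a weaker inhibitor of growth
compound 2 `CN(CCCNS(=O)(=O)c1cc(C(F)(F)F)cc(C(F)(F)F)c1)Cc1ccccc1`: 28000 nM in this assay

Among the measured compounds shown here, compound 2 holds the higher of the two numbers; the only measured step is a 3.0-fold higher number from compound 1 to compound 2 (0.48 log units; beyond the scatter), and compound 1 is its nearest neighbour.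

Compound 3 `O=S(=O)(NCCCNCc1cccc(Cl)c1)c1cc(C(F)(F)F)cc(C(F)(F)F)c1` differs from compound 2 by (3-chlorobenzyl)amino in place of benzyl(methyl)amino on a saturated chain carbon, three bonds along the chain from a sulfonamide nitrogen. For the measured compounds named here, the single step that bears on this change is a 3.0-fold higher number from compound 1 to compound 2 (0.48 log units; beyond the scatter), which runs the other way: it removes a chlorobenzylamino group in favour of benzyl(methyl)amino and costs potency modestly. Compound 3 re-enters a chlorobenzylamino group, the chlorine now carried as named in (3-chlorobenzyl)amino rather than (2-chlorobenzyl)amino. As far as these compounds go, whether the two chlorobenzyl names behave alike is unknown from the data. The expectation is therefore a roughly reversed step, a 2.8-fold lower number from compound 2 to compound 3 (0.45 log units; beyond the scatter), in this assay. Compound 3 is estimated at 10000 nM, within the range 4000 nM to 25000 nM.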

Compound 3, concentration for 50% growth inhibition: 2200 nM
For compound 3 the middle estimate is 4.5-fold (0.66 log units) above the measured one, and the stated range ends above it.
By their numbers in this assay, from the lowest: compound 3; then compound 1; then compound 2.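

In this assay the step of a 4.2-fold lower number from compound 1 to compound 3 (0.63 log units; beyond the scatter) shows that the chlorobenzyl groups are not interchangeable at this place: moving from the 2-chlorophenyl to the 3-chlorophenyl name alone gives a change beyond the scatter. The larger step of a 13-fold lower number from compound 2 to compound 3 (1.10 log units; beyond the scatter) carries two changes together, the chlorine entering and the amine hydrogen returning in place of the methyl on nitrogen, and it goes well beyond the reverse of the earlier step of a 3.0-fold higher number from compound 1 to compound 2 (0.48 log units; beyond the scatter) on that account. No measurement at hand bears on the reason for either step.

Open, as far as these compounds go, is how the large step divides between the chlorine and the amine hydrogen, a question a plain benzylamino group would address. Also open, from the compounds shown here alone, is whether a bromine or methoxy group on the ring, or a longer chain, would keep the potency of compound 3.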